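The source may report more compounds than this note shows. Statements on the series, on what has been measured and on what is new or still open speak of the compounds shown alone.

compound 1 `CCCc1ccc(NC2=CC(=O)c3nc4n(c3C2=O)[C@H]2OC[C@@H](O)[C@H]2OC4)cc1` | 4990 nM
compound 2 `O=C1C=C(Nc2ccccc2F)C(=O)c2c1nc1n2[C@H]2OC[C@@H](O)[C@H]2OC1` | 5120 nM
compound 3 `O=C1C(N2CCCC2)=CC(=O)c2c1nc1n2[C@H]2OC[C@@H](O)[C@H]2OC1` | > 16000 nM (a limit of the assay)

In a functional assay on HeLa cells (Homo sapiens) for inhibition, read by sulforhodamine B assay (on this read-out higher numbers stand for weaker inhibition and lower numbers for stronger inhibition), compound 2 gives 5120 nM and stands within the scatter of compound 1 at 4990 nM. The measured step is a 1.0-fold higher number from compound 1 to compound 2 (0.01 log units; within the scatter). Compound 3 gives > 16000 nM, which is a limit and not a number. Going by the values given here, compound 2 therefore has only one numerical neighbour in this small set.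

Compound 4 `O=C1C=C(Nc2cccc(F)c2)C(=O)c2c1nc1n2[C@H]2OC[C@@H](O)[C@H]2OC1` is the next case, and it differs from compound 2 by 3-fluorophenyl in place of 2-fluorophenyl on an amine nitrogen. In words, this is 3-fluorophenyl in place of 2-fluorophenyl on an amine nitrogen.

Among the compounds with values here, one measured step bears on this change, as it also exchanges the aryl group on that nitrogen. Compound 2 carries 2-fluorophenyl where compound 1 carries 4-propylphenyl, and that exchange gave a 1.0-fold higher number from compound 1 to compound 2 (0.01 log units; within the scatter), so it stayed within the scatter. A single step is a thin basis, but it gives no reason to expect a shift beyond the scatter in this assay in either direction.

The expected change is a 1.0-fold lower number from compound 2 to compound 4 (0.01 log units; within the scatter). For compound 4 the estimated value is 5000 nM, with an expected range of 2300 nM to 11000 nM.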

Compound 4, half-maximal inhibitory concentration: 6440 nM
Estimate against measurement, compound 4: 1.3-fold (0.11 log units) below, and the stated range covers the measured number.
By their numbers in this assay, from the lowest: compounds 1, 2 and 4 (each within the scatter of the next). At a limit, above all of these: compound 3.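

In this assay, moving the fluorine from the 2-fluorophenyl to the 3-fluorophenyl group on the amine nitrogen gives a 1.3-fold higher number from compound 2 to compound 4 (0.10 log units; within the scatter), so this shift in the fluorine's place does not separate the two compounds. Replacing 4-propylphenyl with 3-fluorophenyl at the same nitrogen gives a 1.3-fold higher number from compound 1 to compound 4 (0.11 log units; within the scatter), which makes compounds 1, 2 and 4 a set of three aryl groups with no difference beyond the scatter, whether the ring carries a propyl chain or a fluorine at either of the two places shown. Nothing available explains this flat result, and no measured property of these groups bears on it.

Still open, going by these compounds, is whether 4-fluorophenyl would complete the fluorine series within the same scatter, or whether a phenyl ring carrying a carboxylic acid, a primary amine or a longer chain than propyl would move the number beyond it. The three aryl compounds also leave open whether any change on this nitrogen can move the number in this assay beyond the scatter in either direction.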